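Carbamoyl in place of 3-methylbut-2-en-1-yl on the ring oxygen

This account rests on a few compounds, and the source may have more. Where it says the series, first, only, none or still open, it means among the compounds named here.

Compound 2 `CC(C)=CCOc1cc(=O)n(CCCO)c2c1CC(CC=C(C)C)C(C)(C)C2` gives 7.5% in a functional assay on PANC-1 cells (Homo sapiens) for inhibition, read by MTT assay, with a stated time of 24 h, tested at 10 uM (on this read-out higher numbers stand for more inhibition at the one concentration tested (going by the name of the read-out) and lower numbers for less inhibition), the highest of the three numbers shown, although compound 1 `CC(C)=CCC/C(C)=C/CC1Cc2c(O)cc(=O)n(CCCO)c2CC1(C)C` with 0% and compound 3 `CC(C)=CCC1Cc2c(OCCCNS(=O)(=O)c3ccc(C(F)(F)F)cc3)cc(=O)n(CCCO)c2CC1(C)C` with 0% both lie within the scatter of it, so no order among the three can be read. Compound 4 `CC(C)=CCC1Cc2c(OC(=O)Nc3ccc(F)c(Cl)c3)cc(=O)n(CCCO)c2CC1(C)C` differs from compound 2 by (3-chloro-4-fluorophenyl)carbamoyl in place of 3-methylbut-2-en-1-yl on an oxygen on an aromatic ring. Going by the values given here, no step between measured compounds is available, and none of the three numbers separates from the others beyond the scatter, so the expected step in this assay is estimated as a number 2.5 percentage points higher from compound 2 to compound 4 (within the scatter), with no direction beyond the scatter claimed. Compound 4 is expected to give about 10% in this assay, within a range from 0% to 30%.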

Compound 4, a percentage reported as inhibition, at one concentration (the size of the read-out at that concentration, not a potency): 0%
Compound 4: middle estimate off by 10 percentage points, on the high side; low and high end bracket the measured number.
By their numbers in this assay, from the lowest: compounds 1, 3, 4 and 2 (each within the scatter of the next).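

In this assay the first step available in one place reads a number 7.5 percentage points lower from compound 2 to compound 4 (within the scatter) and concerns an oxygen on an aromatic ring. At this position, (3-chloro-4-fluorophenyl)carbamoyl, with its six-membered aromatic ring and hydrogen-bond donor, therefore cannot be told apart from 3-methylbut-2-en-1-yl, and no direction can be assigned to the change. No supporting measurement bears on this result. Going by these compounds, whether a primary amine or a carboxylic acid on a longer chain at this oxygen would separate from the scatter remains open.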